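Pyridin-2-yl Sulfonamide in a Thiourea Series

A few compounds are considered here, and "the series" means these few. Any claim that something is new, unique, unknown or untested is made for them only; others in the source may bear on it.

Two thiourea sulfonamides sharing one core have been measured. Compound 1 `Cc1noc(NS(=O)(=O)c2ccc(N/C(S)=N\c3ccnc4cc(C(F)(F)F)ccc34)cc2)c1C` gives in a functional assay on HepG2 cells (Homo sapiens) for antiproliferative activity, read by sulforhodamine B assay, with a stated time of 48 h (on this read-out higher numbers stand for weaker inhibition and lower numbers for stronger inhibition), a value of 36800 nM. Compound 2 `O=S(=O)(Nc1nccs1)c1ccc(N/C(S)=N\c2ccnc3cc(C(F)(F)F)ccc23)cc1`, which carries 1,3-thiazol-2-yl on the sulfonamide nitrogen instead, gives in this assay a value of 28200 nM. The step of a 1.3-fold lower number from compound 1 to compound 2 (0.12 log units; within the scatter) lies within the scatter, so compound 2 has the lower of the two numbers but cannot be called stronger than compound 1 on this evidence.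

Compound 3 `O=S(=O)(Nc1ccccn1)c1ccc(N/C(S)=N\c2ccnc3cc(C(F)(F)F)ccc23)cc1` differs from compound 2 by pyridin-2-yl in place of 1,3-thiazol-2-yl on a sulfonamide nitrogen. Among the compounds with values here, the only measured step that bears on this change is the exchange of the ring on the same sulfonamide nitrogen, a 1.3-fold lower number from compound 1 to compound 2 (0.12 log units; within the scatter), which produced no movement beyond the scatter. On that basis the step from compound 2 to compound 3 is expected to be small, with no clear direction: a 1.1-fold higher number from compound 2 to compound 3 (0.03 log units; within the scatter) is the estimated change in this assay. Compound 3 is therefore expected to give in this assay about 30000 nM, within a range from 12000 nM to 75000 nM.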

Compound 3, half-maximal inhibitory concentration: 28000 nM
Estimate against measurement, compound 3: 1.1-fold (0.03 log units) above, within the range that was stated.
By their numbers in this assay, from the lowest: compounds 3, 2 and 1 (each within the scatter of the next).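

Placing pyridin-2-yl on the sulfonamide nitrogen instead of 1,3-thiazol-2-yl gives a 1.0-fold lower number from compound 2 to compound 3 (0.00 log units; within the scatter) in this assay, so exchanging a five-membered aromatic ring with 2 hetero atoms for a six-membered one with 1 hetero atom does not move the number beyond the scatter. The exchange of 3,4-dimethyl-1,2-oxazol-5-yl for pyridin-2-yl reads the same way, with a 1.3-fold lower number from compound 1 to compound 3 (0.12 log units; within the scatter), and all three rings at this position now stand within the scatter of one another, which extends the earlier result from a single exchange between two rings to a set of three that includes a change of ring size. No measurement at hand speaks to why the number stays the same across these rings.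

Going by these compounds, all three compounds carry an aromatic ring on the sulfonamide nitrogen, so it remains open whether a group of another kind there, such as a methyl, a carboxylic acid or a longer alkyl chain, would shift the number in this assay beyond the scatter. On these data alone, it also remains open whether a change elsewhere on the shared core, such as a methoxy in place of the trifluoromethyl, would do so.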